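Swapping the Benzamide Ring on a Quinoline Core

The source may report more compounds than this note shows. Statements on the series, on what has been measured and on what is new or still open speak of the compounds shown alone.

Compound 1 `CCN1CCN(c2cc(C)c3cc(NC(=O)c4ccccc4F)ccc3n2)CC1` is tested in a functional assay on SK-BR-3 cells (Homo sapiens) for antiproliferative activity, read by MTT assay, with a stated time of 72 h (a lower number here means a stronger inhibitor, a higher number a weaker inhibitor), where compound 1 gives 38100 nM. Its companion compound 2 `Cc1cc(N2CCCCC2)nc2ccc(NC(=O)c3ccc(Cl)c(Cl)c3)cc12` shows 42500 nM in this assay ; the two values sit within the usual scatter of each other, so neither stands apart. Compound 3 `CCN1CCN(c2cc(C)c3cc(NC(=O)c4ccc(OC)cc4)ccc3n2)CC1` is not yet measured and differs from compound 1 by 4-methoxyphenyl in place of 2-fluorophenyl on a carbonyl carbon. Among the measured compounds shown here, with no measured step of this kind to lean on, the expected change from compound 1 to compound 3 is a 1.2-fold lower number from compound 1 to compound 3 (0.08 log units; within the scatter), nothing beyond the scatter. Compound 3 is therefore estimated at 32000 nM, likely between 10000 nM and 90000 nM.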

Compound 3, half-maximal inhibitory concentration: 9000 nM
For compound 3 the middle estimate is 3.6-fold (0.55 log units) above the measured one; the whole stated range lies above it.
By their numbers in this assay, from the lowest: compound 3; then compounds 1 and 2 (each within the scatter of the next).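

In this assay, 4-methoxyphenyl in place of 2-fluorophenyl on a carbonyl carbon gives a 4.2-fold lower number from compound 1 to compound 3 (0.63 log units; beyond the scatter), a modest step toward a stronger inhibitor. Among the compounds shown here, this is the first sign that the group at this position can move the number beyond the scatter, which compounds 1 and 2, differing in more than one place, could not show. Nothing available explains why this swap has this effect. Still open, from the compounds shown here alone, is how a plain phenyl or a phenyl carrying an amine would behave here. Also open, going by these compounds, is whether the fluorine leaving or the methoxy entering accounts for the step.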